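A Basic Side Chain Takes the Place of Bromine

The source may hold more compounds than are shown below. What is called first, only, known or untested is meant among the compounds shown, and "the series" means these compounds.

Compound 1 `Nc1ccc(-c2cc(=O)c3c(N)c(F)cc(F)c3o2)cc1F`: in a functional assay on HeLa cells (Homo sapiens) for cytotoxicity, read by neutral red uptake, with a stated time of 3 days (on this read-out lower numbers stand for stronger inhibition and higher numbers for weaker inhibition), compound 1 gives > 100000 nM, a limit of the assay.
Compound 2 `Nc1ccc(-c2cc(=O)c3c(N)c(F)c(Br)c(F)c3o2)cc1F`: in this assay compound 2 gives > 100000 nM, again a limit.
Compound 3 `CCCOCc1c(F)c(N)c2c(=O)cc(-c3ccc(N)c(F)c3)oc2c1F`: in this assay compound 3 gives 78000 nM.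

Compound 2 thus stands at a limit and not at a number, at the limit of > 100000 nM in this assay, at which 2 of the 3 values shown sit. Compound 4 `CN(C)CCCOCc1c(F)c(N)c2c(=O)cc(-c3ccc(N)c(F)c3)oc2c1F` differs from compound 2 by (3-(dimethylamino)propoxy)methyl in place of bromo on an aromatic carbon. The step that bears most on this change is an at least 1.2-fold lower number from compound 2 to compound 3 (0.10 log units; that floor lies within the scatter), in which another alkoxymethyl chain replaced bromo; the step that the two limits leave unreadable from compound 1 to compound 2 adds nothing readable. No shift beyond the scatter is therefore expected in this assay. Compound 4 is expected to sit near the same limit, with an at least 1.2-fold lower number from compound 2 to compound 4 (0.09 log units; that floor lies within the scatter) as the anticipated step. Compound 4 is estimated at 80000 nM, between 30000 nM and 200000 nM.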

Compound 4, half-maximal inhibitory concentration: 12000 nM
Beside the measured number, compound 4's estimate is 6.7-fold (0.82 log units) above it; the measured number lies below the stated range.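

In this assay, at the position ortho to two fluoro groups, the full side chain gives an at least 8.3-fold lower number from compound 2 to compound 4 (0.92 log units; beyond the scatter), and in place of hydrogen it gives an at least 8.3-fold lower number from compound 1 to compound 4 (0.92 log units; beyond the scatter). For the compounds shown here, what the earlier compounds did not show is that the terminal amine matters: with the chain otherwise unchanged, the data give a 6.5-fold lower number from compound 3 to compound 4 (0.81 log units; beyond the scatter), while the floors for the chain without it lay within the scatter. The first two steps are floors, set by a limit of the assay: the limit of > 100000 nM in this assay, at which 2 of the 4 values shown sit.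

Going by these compounds, whether a primary amine, a morpholine or a carboxylic acid at the chain end would do the same stays open. So does the effect of a shorter or longer chain.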